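The source may report more compounds than this note shows. Statements on the series, on what has been measured and on what is new or still open speak of the compounds shown alone.

Compound 1 `Oc1ccc(C2CC(c3ccccc3)=NN2c2ccc(Cl)cc2)cc1` gives 3500 nM in an assay on isolated protein for inhibition of protein kinase C zeta type (Homo sapiens), with a stated time of 4 min; a lower number here means a stronger inhibitor, a higher number a weaker inhibitor. Compound 2 `Oc1ccc(C2CC(c3ccccc3O)=NN2c2ccc(Cl)cc2)cc1` differs from it by hydroxy in place of hydrogen on an aromatic carbon, and in this assay compound 2 gives 1500 nM, which amounts to a 2.3-fold lower number from compound 1 to compound 2 (0.37 log units; beyond the scatter). Compound 3 `Oc1ccc(C2CC(c3ccccc3O)=NN2c2cccc(Cl)c2)cc1F` has a core that differs from compound 1 in more than one place; how the two cores differ is not broken down here. In this assay compound 3 gives 2900 nM, a number that lies within the scatter of both compound 1 and compound 2, so no order among the three is claimed. Compound 4 `Oc1ccc(C2=NN(c3cccc(Cl)c3)C(c3ccc(O)c(F)c3)C2)c(O)c1` carries the same kind of change relative to compound 3, namely (hydroxy in place of hydrogen on an aromatic carbon); the surroundings are not identical, since the new hydroxy in compound 4 sits meta to a hydroxy group and para to a large group, whereas in compound 2 it sits ortho to a large group. Resting on the measured step in compound 1 to compound 2, a modest step of a 1.6-fold lower number from compound 3 to compound 4 (0.21 log units; within the scatter) is expected for compound 4 in this assay. Compound 4 is therefore estimated at 1800 nM, with a range of 700 nM to 4500 nM.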

Compound 4, half-maximal inhibitory concentration: < 100 nM
Compound 4 ended at the assay's limit; the forecaster's own chance of this, stated with the estimate: 5%; middle value at least 18-fold (1.25 log units) from the limit.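

In this assay compound 4 gives < 100 nM, which is a limit of the assay and not a number, so the new step is a bound rather than an exact size. Hydroxy in place of hydrogen on an aromatic carbon lowers the number on both cores, but its size does not carry over, with an at least 29-fold lower number from compound 3 to compound 4 (1.46 log units; beyond the scatter) set against the earlier step: the same change on two cores in this assay, a 2.3-fold lower number (0.37 log units; beyond the scatter) from compound 1 to compound 2 and an at least 29-fold lower number (1.46 log units; beyond the scatter) from compound 3 to compound 4, at least 12-fold (1.09 log units) apart, beyond the scatter of two such steps This shows that the step measured on the core of compound 1 did not predict the step on the core of compound 3, but with only one pair of steps it does not show whether the gap follows from the differing cores or from the new hydroxy's place, meta to a hydroxy group and para to a large group.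

The compounds shown leave open whether a 2,4-dihydroxyphenyl on the core of compound 1 would give a step of similar size. They also leave open whether a methoxy or an amine in place of the new hydroxy would keep the number of compound 4 at the assay's limit.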